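The source may hold more compounds than are shown below. What is called first, only, known or untested is meant among the compounds shown, and "the series" means these compounds.

The measured compounds and their values in a functional assay on A549 cells (Homo sapiens) for inhibition, read by MTT assay, with a stated time of 24 h; on this read-out higher numbers stand for weaker inhibition and lower numbers for stronger inhibition:

compound 1 `CCOC(=O)C1=Cc2ccccc2OC1(OCc1cn(CC(=O)Nc2ccccc2F)nn1)C(F)(F)F` gives 50100 nM.
compound 2 `CCOC(=O)C1=Cc2ccccc2OC1(OCc1cc(-c2ccc([N+](=O)[O-])cc2)no1)C(F)(F)F` reaches only the limit of the assay, > 150000 nM.
compound 3 `O=C(O)C1=Cc2ccccc2OC1(OCc1cc(-c2cccc(C(F)(F)F)c2)no1)C(F)(F)F` likewise reaches only the limit of the assay, > 150000 nM.

Within the data shown here, compound 1 therefore stands as the only compound of the three with a number in this assay ; the other two sit at the limit of > 150000 nM in this assay, at which 2 of the 3 values shown sit. Among the measured compounds shown here, no step between two measured compounds that differ in a single place is available, so there is nothing against which a new exchange can be calibrated.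

Compound 4 `CCOC(=O)C1=Cc2ccccc2OC1(OCc1cn(-c2cccc(OC)c2)nn1)C(F)(F)F` differs from compound 1 in one place: 3-methoxyphenyl in place of ((2-fluorophenyl)carbamoyl)methyl on an aromatic nitrogen. For the measured compounds named here, with no measured step of this kind to lean on, the size and direction of the change can only be guessed. Compound 1 is already weak in this assay , and the limit of the assay lies not far above it. The step from compound 1 to compound 4 is expected to be a 1.5-fold higher number from compound 1 to compound 4 (0.18 log units; within the scatter), a modest move towards weaker inhibition that may or may not exceed the scatter. Compound 4 is estimated at 75000 nM, with a range of 25000 nM to 200000 nM.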

Compound 4, half-maximal inhibitory concentration: > 150000 nM
Compound 4: only a limit was reported (the forecaster's own chance of this, stated with the estimate: 35%); at least 2.0-fold (0.30 log units) between middle value and limit.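

In this assay, among these compounds, replacing ((2-fluorophenyl)carbamoyl)methyl with 3-methoxyphenyl on the aromatic nitrogen gives the first step that can be read in a single place: an at least 2.9-fold higher number from compound 1 to compound 4 (0.47 log units; beyond the scatter). This shows that the group on this nitrogen matters, and that of the two groups tried there, only the ((2-fluorophenyl)carbamoyl)methyl group of compound 1 keeps a number in this read-out. The full size of the step cannot be read, because compound 4, at > 150000 nM, gives only a limit: the limit of > 150000 nM in this assay, at which 3 of the 4 values shown sit.

The exchange changes the chain, the amide hydrogen and the ring substituent all at once, so the compounds shown do not tell which of these accounts for the step. As far as these compounds go, whether a plain phenyl, a benzyl or a (phenylcarbamoyl)methyl group without fluorine on this nitrogen would keep a measurable value remains open.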